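Adding a methoxy to the fluoro compound 2

A few compounds are considered here, and "the series" means these few. Any claim that something is new, unique, unknown or untested is made for them only; others in the source may bear on it.

Measured so far:
Compound 1 `O=C(O)CN1C(=O)/C(=C/c2nc3ccccc3n2Cc2ccccc2)SC1=S` gives 10800 nM in this series
Compound 2 `O=C(O)CN1C(=O)/C(=C/c2nc3ccccc3n2Cc2ccccc2F)SC1=S` gives 1860 nM in this series

In a functional assay on PC-3 cells (Homo sapiens) for cytotoxicity, read by MTT assay, with a stated time of 48 h (a higher number here means a weaker inhibitor, a lower number a stronger inhibitor), compound 2 at 1860 nM holds the lower of the two numbers. Among the measured compounds shown here, the only measured step is a 5.8-fold lower number from compound 1 to compound 2 (0.76 log units; beyond the scatter) and it came with fluoro in place of hydrogen on an aromatic carbon.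

Compound 3 `COc1ccc2c(c1)nc(/C=C1\SC(=S)N(CC(=O)O)C1=O)n2Cc1ccccc1F` has not yet been measured. It differs from compound 2 by methoxy in place of hydrogen on an aromatic carbon. For the measured compounds named here, the fluoro step is the only evidence that bears on this change, and it bears weakly, since it involves another group at another place and no measured compound carries a methoxy. It shows only that one replacement on an aromatic carbon moved the number beyond the scatter in this pair. The data give no direction for methoxy, so the central expectation is no step beyond the scatter, with a modest step either way still possible. The estimated step is a 1.2-fold higher number from compound 2 to compound 3 (0.07 log units; within the scatter) and its margin is wide. In this assay compound 3 is expected at 2200 nM with an estimated range of 750 nM to 6000 nM as its likely span.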

Compound 3, half-maximal inhibitory concentration: 24700 nM
Compound 3: the middle estimate sits 11-fold (1.05 log units) below what was measured, and the stated range ends below it.
By their numbers in this assay, from the lowest: compound 2; then compound 1; then compound 3.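

Placing methoxy on the six-membered aromatic ring of carbon only, part of the fused system of two rings, gives a 13-fold higher number from compound 2 to compound 3 (1.12 log units; beyond the scatter) in this assay, the largest step in this short series. Among the compounds shown here, the only earlier step, a 5.8-fold lower number from compound 1 to compound 2 (0.76 log units; beyond the scatter) with fluoro in place of hydrogen, lies at another place and runs the other way, so this result is the first sign that the number responds to a change on this ring of the shared core. Together the two steps show that replacing hydrogen on an aromatic carbon can move the number strongly in either direction in this series, and that the direction seen at one place does not carry over to the other.

As far as these compounds go, it remains open whether this rise belongs to methoxy itself or to any group at this carbon, a question that a hydroxy, a chlorine or an amine at the same place would help to settle, as would methoxy at another carbon of that ring. Nothing among the data shown accounts for the size or direction of this step.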